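Chloro to Tert-Butyl, Repeated on a Second Core

The source may report more compounds than this note shows. Statements on the series, on what has been measured and on what is new or still open speak of the compounds shown alone.

Of the compounds shown here, three have been measured in a functional assay on A549 cells (Homo sapiens) for cytotoxicity, read by MTT assay, with a stated time of 72 h; on this read-out lower numbers stand for stronger inhibition and higher numbers for weaker inhibition. Compound 2 `CN(C)Cc1ccc2nc(NC(=O)N/N=C/c3cn(Cc4ccc(Cl)cc4)c4ccccc34)sc2c1` gives 840 nM in this assay. Compound 1 `CN(C)Cc1ccc2nc(NC(=O)N/N=C/c3cn(Cc4ccc(C(C)(C)C)cc4)c4ccccc34)sc2c1` differs from compound 2 by tert-butyl in place of chloro on an aromatic carbon, and in this assay compound 1 gives 1850 nM, a step of a 2.2-fold higher number from compound 2 to compound 1 (0.34 log units; beyond the scatter). Compound 3 `CC1CCN(Cc2ccc3nc(NC(=O)N/N=C/c4cn(Cc5ccc(Cl)cc5)c5ccccc45)sc3c2)CC1` differs from compound 2 by 4-methylpiperidin-1-yl in place of dimethylamino on a saturated chain carbon bound to an aromatic carbon, and in this assay compound 3 gives 2030 nM, a step of a 2.4-fold higher number from compound 2 to compound 3 (0.38 log units; beyond the scatter). The values of compound 1 and compound 3 lie within the usual scatter of each other, so nothing separates them.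

Compound 4 `CC1CCN(Cc2ccc3nc(NC(=O)N/N=C/c4cn(Cc5ccc(C(C)(C)C)cc5)c5ccccc45)sc3c2)CC1` has not yet been measured. It shares the core of compound 3 and differs from it by tert-butyl in place of chloro on an aromatic carbon. This is the same change as from compound 2 to compound 1, made at a place described in identical words: on an aromatic carbon of a six-membered aromatic ring of carbon only, para to a large group. Among the compounds with values here, the only example of this change so far weakened inhibition modestly, and it has been seen just once, on one core.

For compound 4 the expected step is a 2.1-fold higher number from compound 3 to compound 4 (0.33 log units; beyond the scatter). That expectation rests on compound 1, because the same change gave a 2.2-fold higher number from compound 2 to compound 1 (0.34 log units; beyond the scatter), with a wide range to allow for a single example. Compound 4 is therefore estimated at 4300 nM, between 2000 nM and 9500 nM.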

Compound 4, half-maximal inhibitory concentration: 3710 nM
Beside the measured number, compound 4's estimate is 1.2-fold (0.06 log units) above it; measured number inside the range.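

In this assay, tert-butyl in place of chloro on the core of compound 3 gives a 1.8-fold higher number from compound 3 to compound 4 (0.26 log units; within the scatter), and this agrees with the step seen earlier on the other core: the same change on two cores in this assay, a 2.2-fold higher number (0.34 log units; beyond the scatter) from compound 2 to compound 1 and a 1.8-fold higher number (0.26 log units; within the scatter) from compound 3 to compound 4, 1.2-fold (0.08 log units) apart, within the scatter of two such steps. The second change, 4-methylpiperidin-1-yl in place of dimethylamino, gives a 2.0-fold higher number from compound 1 to compound 4 (0.30 log units; within the scatter) when read on the two tert-butyl compounds, and it also agrees with its earlier step: the same change on two cores in this assay, a 2.4-fold higher number (0.38 log units; beyond the scatter) from compound 2 to compound 3 and a 2.0-fold higher number (0.30 log units; within the scatter) from compound 1 to compound 4, 1.2-fold (0.08 log units) apart, within the scatter of two such steps. These four compounds show that each change gave steps of matching size on both cores, but the two new steps lie within the scatter on their own, and a single pair of cores cannot show that either change would carry over the same way to further cores in the series.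

On these data alone, it remains open whether other groups in the same place on the aromatic ring, such as methyl, methoxy or trifluoromethyl, would give steps that fit with those of chloro and tert-butyl. As far as these compounds go, it is equally open how other amines on the saturated chain carbon, such as morpholine or diethylamine, would compare with dimethylamino and 4-methylpiperidin-1-yl, and whether any of these steps would hold on other cell types.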